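Changing the aryl group on the saturated ring carbon

The source may hold more compounds than are shown below. What is called first, only, known or untested is meant among the compounds shown, and "the series" means these compounds.

Measured compounds:
compound 1 `COc1ccc(C2N=C(SCc3cccc(Cl)c3)NC(C)=C2C(=O)Nc2ccc(F)cc2)cc1OC` with 15.5%
compound 2 `COc1ccc(C2N=C(SCc3ccc(F)cc3)NC(C)=C2C(=O)Nc2ccc(F)cc2)cc1OC` with 17%
compound 3 `CC1=C(C(=O)Nc2ccc(F)cc2)C(c2ccc([N+](=O)[O-])cc2)N=C(SCc2cccc(Cl)c2)N1` with 12.9%

In a functional assay on the whole organism (artery, strain albino) with Rattus norvegicus as the target, with a stated time of 720 min, at a dose of 10 mg/kg by the oral route (on this read-out higher numbers stand for more inhibition at the one dose given (going by the name of the read-out) and lower numbers for less inhibition), compound 2 gives the largest of the three numbers, but its lead over the others is small: a number 1.5 percentage points higher from compound 1 to compound 2 (within the scatter), and compound 3 sits only somewhat further down. None of the three compounds can be set apart from the others on these figures.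

Compound 4 `CC1=C(C(=O)Nc2ccc(F)cc2)C(c2ccc([N+](=O)[O-])cc2)N=C(SCc2ccc(F)cc2)N1` has not been measured. It differs from compound 2 in one place: 4-nitrophenyl in place of 3,4-dimethoxyphenyl on a saturated ring carbon. The same exchange has already been made once within this series, between compound 1 and compound 3, where it produced a number 2.6 percentage points lower from compound 1 to compound 3 (within the scatter). Among the compounds with values here, that is the only step that bears directly on the change in hand, and it stayed inside the usual scatter. The other measured step, from compound 1 to compound 2, concerns a different position and does not inform this one.

On that basis compound 4 is expected to lie close to compound 2, with at most a small drop: the estimated step is a number 2.5 percentage points lower from compound 2 to compound 4 (within the scatter). The estimate for compound 4 is 14.5%, expected to fall between 5% and 24%.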

Compound 4, a percentage reported as inhibition, in the whole organism at one dose (the size of the read-out at that dose, not a potency): 19.6%
The estimate for compound 4 lay 5.1 percentage points below the measured number; measured number inside the range.
By their numbers in this assay, from the lowest: compounds 3, 1, 2 and 4 (each within the scatter of the next).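

In this assay, the exchange of 3,4-dimethoxyphenyl for 4-nitrophenyl on the saturated ring carbon, now read on a second core, gives a number 2.6 percentage points higher from compound 2 to compound 4 (within the scatter), so the two readings of this change do not point the same way: the same change on two cores in this assay, a number 2.6 percentage points lower (within the scatter) from compound 1 to compound 3 and a number 2.6 percentage points higher (within the scatter) from compound 2 to compound 4, 5.2 percentage points apart, within the scatter of two such steps

The new compound also gives a second reading of the change on the saturated chain carbon bound to sulfur, 4-fluorophenyl in place of 3-chlorophenyl, with a number 6.7 percentage points higher from compound 3 to compound 4 (within the scatter), and this too agrees with the earlier reading as far as the scatter allows: the same change on two cores in this assay, a number 1.5 percentage points higher (within the scatter) from compound 1 to compound 2 and a number 6.7 percentage points higher (within the scatter) from compound 3 to compound 4, 5.2 percentage points apart, within the scatter of two such steps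

Taken together, the four compounds show that neither change has a direction that can be read at this dose, and that the two aryl groups on the saturated ring carbon cannot be told apart on either core.

From the compounds shown here alone, it remains open whether a different kind of group on that ring carbon, such as an aminophenyl, a carboxylic acid on the phenyl ring or a plain alkyl chain, would move the number beyond the scatter. With a single dose, the read-out also leaves the potency of all four compounds open.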